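From a 4-chlorophenyl limit to a 3-bromophenyl estimate

The compounds below may be only part of what the source reports. "The series", "measured", "known", "first", "only" and "open" are said of these compounds alone.

In a functional assay on SK-MEL-28 cells (Homo sapiens) for cytotoxicity, read by CCK-8 assay, with a stated time of 24 h (on this read-out higher numbers stand for weaker inhibition and lower numbers for stronger inhibition), compound 3 (`COc1ccccc1Oc1c(N)nc(-c2ccc(Cl)cc2)nc1OCCO`) reads > 80000 nM and this is a limit of the assay, not a measured number. Two relatives share its core. Compound 1 (`COc1ccccc1Oc1c(N)nc(-c2ccc(F)cc2)nc1OCCO`) gives 20100 nM in this assay on the same scale. Compound 2 (`COc1ccccc1Oc1c(N)nc(-c2cccc(Cl)c2)nc1OCCO`) gives 4170 nM in the same way.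

Compound 4 (`COc1ccccc1Oc1c(N)nc(-c2cccc(Br)c2)nc1OCCO`) has not been measured yet. The change is 3-bromophenyl in place of 4-chlorophenyl on an aromatic carbon so 3-bromophenyl takes the place of 4-chlorophenyl, on the aromatic carbon between two ring nitrogen atoms.

The closest measured step is an at least 19-fold higher number from compound 2 to compound 3 (1.28 log units; beyond the scatter) and it is large, with 4-chlorophenyl in place of 3-chlorophenyl. Two further steps complete the picture: a 4.8-fold lower number from compound 1 to compound 2 (0.68 log units; beyond the scatter) is modest and an at least 3.9-fold higher number from compound 1 to compound 3 (0.59 log units; beyond the scatter) is at least modest. For the measured compounds named here, no bromine-bearing compound has been measured, so the best guide is compound 2 at 4170 nM with its 3-chlorophenyl group.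

A large step towards a lower number, meaning stronger inhibition, is therefore expected in this assay and is estimated as an at least 16-fold lower number from compound 3 to compound 4 (1.20 log units; beyond the scatter) from these few data. The estimate for compound 4 is 5000 nM with an expected range from 1800 nM to 15000 nM as the likely span.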

Compound 4, half-maximal inhibitory concentration: 4040 nM
For compound 4 the middle estimate is 1.2-fold (0.09 log units) above the measured one; the measured number falls inside the stated range.
By their numbers in this assay, from the lowest: compounds 4 and 2 (each within the scatter of the next); then compound 1. At a limit, above all of these: compound 3.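

The new result shows that, in this assay, 3-bromophenyl and 3-chlorophenyl cannot be told apart, with a 1.0-fold lower number from compound 2 to compound 4 (0.01 log units; within the scatter), so the good reading of the 3-chlorophenyl compound no longer stands alone and does not depend on chlorine as the halogen. Compound 4 also reads well below the compound carrying 4-fluorophenyl, with a 5.0-fold lower number from compound 1 to compound 4 (0.70 log units; beyond the scatter), so both 3-halophenyl compounds now sit apart from both 4-halophenyl compounds, and no compound shown goes against this. The step from the 4-chlorophenyl compound, an at least 19-fold lower number from compound 3 to compound 4 (1.29 log units; beyond the scatter), is large but gives only a minimum size, since compound 3 reads at a limit of the assay and not at a number: the limit of > 80000 nM in this assay, at which 1 of the 4 values shown sits.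

On these data alone, all four compounds carry a halogen on this phenyl ring, so it remains open whether a methoxy group, a nitrile or an amine in the same place would keep the activity of compound 4. As far as these compounds go, it is equally open whether a 4-bromophenyl group would read as weakly as 4-chlorophenyl, or whether the gap between the two positions holds for bromine too.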